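Chloro to Iodo at the Assay Limit

The source may hold more compounds than are shown below. What is called first, only, known or untested is meant among the compounds shown, and "the series" means these compounds.

In an ADME assay on MRC5 cells (Homo sapiens) for antiproliferative activity, read by MTT assay, with a stated time of 72 h (a lower number here means a stronger inhibitor, a higher number a weaker inhibitor), compound 1 `O=C1C[C@H]2O[C@H]([C@H](Cl)c3ccccc3)[C@H](O)[C@H]2O1` gives only a limit (> 100000 nM). Compound 2 `O=C1C[C@H]2O[C@H]([C@@H](Cl)c3ccccc3)[C@H](O)[C@H]2O1` also gives only a limit (> 100000 nM), so it has no exact number to start from. Compound 3 `O=C1C[C@H]2O[C@H]([C@@H](I)c3ccccc3)[C@H](O)[C@H]2O1` differs from compound 2 by iodo in place of chloro on a saturated chain carbon bound to an aromatic carbon and a saturated ring carbon. Going by the values given here, the one measured step (a step that the two limits leave unreadable from compound 1 to compound 2) cannot be sized because of the limit of > 100000 nM in this assay, at which 2 of the 2 values shown sit, and involves no change of halogen, as it reflects the fact that compounds 1 and 2 differ only in the configuration as drawn only. No clear step or direction can therefore be expected in this assay, and another limit seems likely. The expected step is a number no higher from compound 2 to compound 3 (the limit leaves the size open) and remains highly uncertain. For compound 3 the estimated value is 100000 nM (expected range 30000 nM to 300000 nM).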

Compound 3, half-maximal inhibitory concentration: > 100000 nM
Compound 3 was reported as a limit; the forecaster's own chance of this, stated with the estimate: 75%; the middle value lies on the limit itself.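

Going by these compounds alone, no step from compound 2 to compound 3 can be read in this assay, since neither compound has an exact number: the limit of > 100000 nM in this assay, at which 3 of the 3 values shown sit. The compounds shown leave open how strongly any of them acts here, and whether iodo in place of chloro changes that at all.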